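The source may report more compounds than this note shows. Statements on the series, on what has been measured and on what is new or still open speak of the compounds shown alone.

Measured compounds:
- compound 1, `Cc1cc(-n2cc(C(=O)Nc3cc(F)cc(F)c3)c(=O)c3ccc(N(C)C)nc32)ccc1OCCCCCCC[N+]1(C)CCCCC1`: 54.4%
- compound 2, `CN(C)c1ccc2c(=O)c(C(=O)Nc3cc(F)cc(F)c3)cn(-c3ccc(OCCCCCCC[N+]4(C)CCCCC4)c(Cl)c3)c2n1`: "not active" (no number reported)

Of the compounds shown here, two have been measured in an assay on LX2 cells for inhibition of COL1A1 promoter (Homo sapiens), read by a luciferase reporter, with a stated time of 24 h, tested at 50 uM; a lower number here means a weaker effect, a higher number a stronger effect of the compound at the concentration tested. Within the data shown here, compound 1 gives 54.4% there, the only numeric value in the set. Among the measured compounds shown here, compound 2 is reported in this assay as "not active" (no number reported), with no number attached, so no sized step between compound 1 and compound 2 can be stated; the two results show only that one compound gave a measurable effect and the other did not.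

Compound 3, `Cc1cc(-n2cc(C(=O)Nc3cc(F)cc(F)c3)c(=O)c3ccc(N(C)C)nc32)ccc1OCCCCCCC[N+]1(C)CCN(C)CC1`, has not yet been measured. It keeps the shared core of compound 1 and changes only the charged ring at the end of the chain: a group of 8 heavy atoms (6 carbon, 2 nitrogen; one six-membered non-aromatic ring with 2 hetero atoms) in place of a group of 7 heavy atoms (6 carbon, 1 nitrogen; one six-membered non-aromatic ring with 1 hetero atom), on a saturated chain carbon, seven bonds along the chain from an oxygen on an aromatic ring

For the measured compounds named here, no pair of measured compounds separated by a single change is available, so there is no measured step to lean on. The charged ring is kept and one ring atom becomes a nitrogen, which is a modest change at the far end of a long chain. The expected step of a number 9.4 percentage points lower from compound 1 to compound 3 (within the scatter) is therefore small, a slight drop that need not exceed the usual scatter. Compound 3 is estimated at 45%, within a range of 20% to 65%.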

Compound 3, a percentage reported as inhibition, at one concentration (the size of the read-out at that concentration, not a potency): 32%
For compound 3 the middle estimate is 13 percentage points above the measured one; measured number inside the range.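

The step in this assay, a number 22.4 percentage points lower from compound 1 to compound 3 (beyond the scatter), shows that the far end of the long chain is not a neutral spot: a change confined to the charged ring, on a saturated chain carbon seven bonds along the chain from an oxygen on an aromatic ring, moves the read-out by more than repeat measurements would. Both rings carry a net charge of +1, so keeping that charge did not keep the read-out, while the entering ring, with 2 hetero atoms and 1 hydrogen-bond acceptor, still leaves compound 3 with a measurable effect. No measurement here bears on why this single change lowers the number.

The compounds shown leave open whether the drop belongs to the second ring nitrogen itself or to the larger group as a whole, and a morpholinium ring, with an oxygen in place of that nitrogen, or a smaller pyrrolidinium ring on the same chain carbon would help to separate the two. They also leave open how far the step holds with a shorter or longer chain, and, as each value comes from a single concentration, how the two compounds differ in potency.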